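Chloro to methyl para to the enone: expected cytotoxicity

The compounds below may be only part of what the source reports. "The series", "measured", "known", "first", "only" and "open" are said of these compounds alone.

Measured compounds:
Compound 1, `Cc1c(C(=O)/C=C/c2cccc([N+](=O)[O-])c2)[n+]([O-])c2ccccc2[n+]1[O-]`, in a functional assay on HL-60 cells (Homo sapiens) for cytotoxicity, with a stated time of 48 h (a higher number here means that more compound is tolerated, a lower number that less compound is tolerated), gives 62000 nM.
Compound 2, `COc1ccc(/C=C/C(=O)c2c(C)[n+]([O-])c3ccccc3[n+]2[O-])cc1OC`, in this assay gives 14000 nM.
Compound 3, `Cc1c(C(=O)/C=C/c2ccc(Cl)cc2)[n+]([O-])c2ccccc2[n+]1[O-]`, in this assay gives 11000 nM.

Compound 3 holds the lowest of the three numbers in this assay. Compound 2 sits nearest, within the usual scatter, whereas compound 1 lies well beyond it. Compound 4, `Cc1ccc(/C=C/C(=O)c2c(C)[n+]([O-])c3ccccc3[n+]2[O-])cc1`, has not yet been measured; it differs from compound 3 by methyl in place of chloro on an aromatic carbon. Going by the values given here, no step between measured compounds isolates such a change, so the data give no direction for it. The expected step is a 1.1-fold higher number from compound 3 to compound 4 (0.04 log units; within the scatter), which stays within the scatter. In this assay compound 4 is estimated at 12000 nM, with a range from 5000 nM to 30000 nM.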

Compound 4, half-maximal cytotoxic concentration: 4100 nM
The estimate for compound 4 lay 2.9-fold (0.47 log units) above the measured number; the whole stated range lies above it.
By their numbers in this assay, from the lowest: compound 4; then compounds 3 and 2 (each within the scatter of the next); then compound 1.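

In this assay, methyl in place of chloro on an aromatic carbon para to a large group gives a 2.7-fold lower number from compound 3 to compound 4 (0.43 log units; beyond the scatter). This is the first step among these compounds that isolates a single change, and it shows that this position responds, modestly, to the exchange of one heavy atom for another. No supporting data bear on why the number moves.

The compounds shown leave open how an ethyl, an amine or a fluoro group at this place would compare with methyl and chloro. They also leave open whether the step would hold on a different core.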